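The compounds below may be only part of what the source reports. "The series", "measured", "known", "first", "only" and "open" are said of these compounds alone.

Compound 1 `COC(=O)/C=C/c1cccc(N(Cc2ccc(/C=C/c3scnc3C)cc2)C(=O)C2CCCCC2)c1` carries a cyclohexyl on the carbonyl carbon and a 2-(4-methyl-1,3-thiazol-5-yl)ethenyl on the benzyl ring. In an assay on isolated protein with Bile acid receptor (Homo sapiens) as the target (on this read-out higher numbers stand for an effect only at larger amounts of compound and lower numbers for an effect already at smaller amounts), compound 1 gives 227 nM, the second highest of the three numbers measured; compound 2 `COC(=O)/C=C/c1cccc(N(Cc2ccc(/C=C/c3scnc3C)cc2)C(=O)C(C)C)c1` gives 228 nM and compound 3 `COC(=O)/C=C/c1cccc(N(Cc2ccc(/C=C/C(=O)OC(C)(C)C)cc2)C(=O)c2ccco2)c1` gives 205 nM, and both lie within the scatter of compound 1. Going by the values given here, the one measured step, a 1.0-fold higher number from compound 1 to compound 2 (0.00 log units; within the scatter), concerns the group on the carbonyl carbon and does not touch the place changed here.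

Compound 4 `COC(=O)/C=C/c1cccc(N(Cc2ccc(Br)cc2)C(=O)C2CCCCC2)c1` differs from compound 1 in one place: bromo in place of 2-(4-methyl-1,3-thiazol-5-yl)ethenyl on an aromatic carbon. Among the compounds with values here, no measured pair covers this change; compound 3, which carries a different group at that same position, shows a value within the scatter of compound 1, but that pair was not computed as a step. Because compound 1 sits at 227 nM and the change removes a large group for a single atom, a weaker result is expected: the estimate for compound 4 is 1100 nM (range 300 nM to 4500 nM), a step of a 4.8-fold higher number from compound 1 to compound 4 (0.69 log units; beyond the scatter).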

Compound 4, half-maximal effective concentration: > 1000 nM
Compound 4: a limit, no number; the forecaster's own chance of this, stated with the estimate: 15%; the middle value lies beyond the limit too.
By their numbers in this assay, from the lowest: compounds 3, 1 and 2 (each within the scatter of the next). At a limit, above all of these: compound 4.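

Compound 4 stands at a limit of this assay, which is not a number: the limit of > 1000 nM in this assay, at which 1 of the 4 values shown sits. Even so, the step can be read, as an at least 4.4-fold higher number from compound 1 to compound 4 (0.64 log units; beyond the scatter), and it is the first step shown that lies beyond the scatter, since the only earlier step, at the carbonyl carbon, did not. This aromatic carbon therefore responds to its substituent: with the cyclohexyl on the carbonyl carbon held constant, bromo does not stand in for the 2-(4-methyl-1,3-thiazol-5-yl)ethenyl.

From the compounds shown here alone, how far compound 4 lies beyond its limit stays open, so the full size of the step is unknown. The compounds shown also leave open whether the five-membered aromatic ring or the double bond matters more, as an unsubstituted ethenyl, a phenyl or a directly attached thiazole at this carbon could tell.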